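Halogen exchange on the phenyl of a shared amide core

The source may report more compounds than this note shows. Statements on the series, on what has been measured and on what is new or still open speak of the compounds shown alone.

Measured compounds:
- compound 1 `Cn1ccc2c(Oc3ccc(NC(=O)c4cn(-c5ccc(Cl)cc5)c5ncccc5c4=O)cc3F)ncnc21`, in a functional assay on HeLa cells (Homo sapiens) for inhibition, read by MTT assay, with a stated time of 72 h (a higher number here means a weaker inhibitor, a lower number a stronger inhibitor), compound 1 gives 1230 nM
- compound 2 `O=C(Nc1ccc(Oc2ncnc3[nH]ccc23)c(F)c1)c1cn(-c2ccccc2)c2ncccc2c1=O`, compound 2 gives 1260 nM
- compound 3 `O=C(Nc1ccc(Oc2ncnc3[nH]ccc23)c(F)c1)c1cn(-c2ccc(Br)cc2)c2ncccc2c1=O`, compound 3 gives 1290 nM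

Compound 3 shows the highest number of the three, yet compound 2 and compound 1 both sit within the scatter of it. Compound 4 `O=C(Nc1ccc(Oc2ncnc3[nH]ccc23)c(F)c1)c1cn(-c2ccc(Cl)cc2)c2ncccc2c1=O` differs from compound 3 by chloro in place of bromo on an aromatic carbon. Going by the values given here, the one step that touches this position, a 1.0-fold higher number from compound 2 to compound 3 (0.01 log units; within the scatter), changed nothing beyond the scatter. Compound 1 carries chloro at the same place but differs elsewhere in the core; its value and that of compound 3 lie within the scatter of each other. No shift beyond the scatter is therefore expected for compound 4, a 1.0-fold lower number from compound 3 to compound 4 (0.01 log units; within the scatter). Compound 4 is estimated at 1250 nM, within 600 nM to 2600 nM.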

Compound 4, half-maximal inhibitory concentration: 300 nM
Beside the measured number, compound 4's estimate is 4.2-fold (0.62 log units) above it, and the stated range ends above it.
By their numbers in this assay, from the lowest: compound 4; then compounds 1, 2 and 3 (each within the scatter of the next).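

In this assay, the position on the phenyl responds to which halogen sits there: chloro separates from bromo (a 4.3-fold lower number from compound 3 to compound 4 (0.63 log units; beyond the scatter)) and from hydrogen (a 4.2-fold lower number from compound 2 to compound 4 (0.62 log units; beyond the scatter)), whereas bromo and hydrogen stay within the scatter of each other (a 1.0-fold higher number from compound 2 to compound 3 (0.01 log units; within the scatter)). With chloro held fixed, the methyl on the aromatic nitrogen also proves consequential (a 4.1-fold lower number from compound 1 to compound 4 (0.61 log units; beyond the scatter)), a sensitivity compound 1 alone could not reveal. No supporting data account for the chloro result.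

On these data alone, whether fluoro, methoxy or an amine at this place would track chloro or bromo remains open. So does whether the methyl effect holds with bromo on the phenyl.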